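The source may hold more compounds than are shown below. What is called first, only, known or untested is meant among the compounds shown, and "the series" means these compounds.

Three compounds have been measured in an assay on H4 cells for inhibition of Fatty-acid amide hydrolase 1 (Homo sapiens); on this read-out higher numbers stand for weaker inhibition and lower numbers for stronger inhibition:

Compound 1, `CCCCCCCCOc1ccc(NC(=O)Oc2ccccc2F)cc1`: 19 nM
Compound 2, `CCCCCOc1ccc(NC(=O)ON=C(C)C)cc1`: 28 nM
Compound 3, `CCOc1ccc(NC(=O)O/N=C/c2ccccc2)cc1`: 81 nM

All three share a core with an oxygen-linked chain on one side of the aromatic ring and a carbamate on the other; the chain and the carbamate end differ from one compound to the next. In this assay compound 3 has the highest number of the three. Compound 2 sits nearest to it, and its number is lower by a gap that lies beyond the usual scatter; compound 1 lies furthest away, also with a lower number beyond the scatter. Compounds 1 and 2 both carry longer chains than compound 3, though they also differ from it at the carbamate end, so no single change can be read out of those pairs.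

Compound 4, `CCCCCCCCCCCCOc1ccc(NC(=O)O/N=C/c2ccccc2)cc1`, has not been measured yet. It keeps the carbamate end of compound 3 and differs in one place: decyl in place of hydrogen on a saturated chain carbon, two bonds along the chain from an oxygen on an aromatic ring. Within the data shown here, with no directly comparable step available, the expectation rests on the two longer-chain compounds, compound 1 with 19 nM and compound 2 with 28 nM, both lower than compound 3. For compound 4 a drop beyond the scatter is therefore expected, a 3.7-fold lower number from compound 3 to compound 4 (0.57 log units; beyond the scatter). Compound 4 is estimated at 22 nM, with a likely range from 6 nM to 80 nM.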

Compound 4, half-maximal inhibitory concentration: 2.4 nM
Compound 4: middle estimate off by 9.2-fold (0.96 log units), on the high side; measured number outside the range, below it.
By their numbers in this assay, from the lowest: compound 4; then compounds 1 and 2 (each within the scatter of the next); then compound 3.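

With the carbamate end held fixed, the effect of the chain can now be read on its own: in this assay, decyl in place of hydrogen on a saturated chain carbon, two bonds along the chain from an oxygen on an aromatic ring, gives a 34-fold lower number from compound 3 to compound 4 (1.53 log units; beyond the scatter), a large step. This position therefore accepts an addition of 10 heavy atoms, none of them a hydrogen-bond donor or acceptor, and the inhibition becomes stronger rather than weaker. Nothing in the available data gives a reason for this step.

On these data alone, a single step has only two end points, so it remains open whether the number falls steadily as the chain grows or drops only once the chain reaches a certain length, and whether a longer chain would lower it further. As far as these compounds go, it is equally open whether the stronger inhibition depends on a plain carbon chain or would survive in a chain carrying an amine or a carboxylic acid.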